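A few compounds are considered here, and "the series" means these few. Any claim that something is new, unique, unknown or untested is made for them only; others in the source may bear on it.

Measured so far in a functional assay on the whole organism for inhibition, with Rattus norvegicus as the target, read by cytopathic effect and paw edema, at a dose of 100 mg/kg by the oral route; a lower number here means less inhibition, a higher number more inhibition at the dose given (going by the name of the read-out): compound 1 `O=C(NN1CCOCC1)c1c(O)c2cccnc2n(-c2ccccc2)c1=O` gives -26.2%; compound 2 `Nc1ccc(NC(=O)c2c(O)c3cccnc3n(-c3ccccc3)c2=O)cc1` gives 0%; compound 3 `COc1cccc(NC(=O)c2c(O)c3cccnc3n(-c3ccccc3)c2=O)c1` gives 20.7%.

Compound 3 stands highest of the three, with compound 2 nearest and compound 1 furthest, both gaps beyond the scatter. Compound 4 `O=C(Nc1cccc([N+](=O)[O-])c1)c1c(O)c2cccnc2n(-c2ccccc2)c1=O` differs from compound 3 in one place: nitro in place of methoxy on an aromatic carbon. Within the data shown here, no measured step exchanges one group on the 3-methoxyphenyl ring for another; the closest is a number 20.7 percentage points higher from compound 2 to compound 3 (beyond the scatter), where one substituted phenyl replaced another, while a number 46.9 percentage points higher from compound 1 to compound 3 (beyond the scatter) and a number 26.2 percentage points higher from compound 1 to compound 2 (beyond the scatter) concern the morpholin-4-yl group. Only a modest step in either direction is therefore expected for compound 4, well short of the earlier ones. The estimate for compound 4 is 15% (range -15% to 45%), which means an expected step of a number 5.7 percentage points lower from compound 3 to compound 4 (within the scatter).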

Compound 4, a percentage reported as inhibition, in the whole organism at one dose (the size of the read-out at that dose, not a potency): 7.4%
Compound 4: the middle estimate sits 7.6 percentage points above what was measured; the range from low to high includes it.
By their numbers in this assay, from the lowest: compound 1; then compounds 2 and 4 (each within the scatter of the next); then compound 3.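

In this assay, the group on this aromatic carbon matters on its own: nitro in place of methoxy gives a number 13.3 percentage points lower from compound 3 to compound 4 (beyond the scatter) with the rest of the molecule unchanged. Compound 4 still gives a number 33.6 percentage points higher from compound 1 to compound 4 (beyond the scatter) yet a number 7.4 percentage points higher from compound 2 to compound 4 (within the scatter) so all three substituted phenyl compounds now read above the morpholin-4-yl compound 1. No data here explain the drop from methoxy to nitro.

Going by these compounds, how an amine or a carboxylic acid on this carbon would read stays open. So does the effect of moving methoxy or nitro to another ring carbon.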